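Halobenzyl exchange on two cores in one cytotoxicity series

This account rests on a few compounds, and the source may have more. Where it says the series, first, only, none or still open, it means among the compounds named here.

Compound 1 `Cc1ccc(/C=C2\CN(C(=S)SCc3cn(Cc4ccc(F)cc4)nn3)C/C(=C\c3ccc(C)cc3)C2=O)cc1` and compound 2 `Cc1ccc(/C=C2\CN(C(=S)SCc3cn(Cc4cccc(Cl)c4)nn3)C/C(=C\c3ccc(C)cc3)C2=O)cc1` form one pair; compound 3 `O=C1/C(=C/c2ccccc2F)CN(C(=S)SCc2cn(Cc3ccc(F)cc3)nn2)C/C1=C\c1ccccc1F` and the unmeasured compound 4 `O=C1/C(=C/c2ccccc2F)CN(C(=S)SCc2cn(Cc3cccc(Cl)c3)nn2)C/C1=C\c1ccccc1F` form a second pair built on the same change: 3-chlorophenyl in place of 4-fluorophenyl on a saturated chain carbon bound to an aromatic nitrogen, and again (3-chlorophenyl in place of 4-fluorophenyl on a saturated chain carbon bound to an aromatic nitrogen). The difference between the two cores is not broken down here. In a functional assay on MDA-MB-231 cells (Homo sapiens) for cytotoxicity, read by MTT assay, with a stated time of 24 h (on this read-out lower numbers stand for stronger inhibition and higher numbers for weaker inhibition), compound 1 gives 45600 nM, and compound 2 gives 83000 nM; the step is a 1.8-fold higher number from compound 1 to compound 2 (0.26 log units; within the scatter). Compound 3 gives 58800 nM in this assay, and its gaps to compound 1 and compound 2 both sit within the scatter, so none of the three can be ordered. Among the measured compounds shown here, for compound 4 a step of similar size is expected, a 1.6-fold higher number from compound 3 to compound 4 (0.21 log units; within the scatter), resting on a 1.8-fold higher number from compound 1 to compound 2 (0.26 log units; within the scatter) as the single measured instance of this change. Compound 4 is therefore estimated in this assay at 95000 nM, within 45000 nM to 200000 nM.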

Compound 4, half-maximal inhibitory concentration: > 100000 nM
Compound 4 was reported as a limit (the forecaster's own chance of this, stated with the estimate: 15%); at least 1.0-fold (0.02 log units) between middle value and limit.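

Carried onto the core of compound 3, the exchange of 4-fluorobenzyl for 3-chlorobenzyl gives an at least 1.7-fold higher number from compound 3 to compound 4 (0.23 log units; that floor lies within the scatter). Compound 4 carries a limit of the assay and not a number, > 100000 nM: the limit of > 100000 nM in this assay, at which 1 of the 4 values shown sits. The two steps are compatible with the change carrying over from one core to the other, but they establish neither a shared size nor a difference: the same change on two cores in this assay, a 1.8-fold higher number (0.26 log units; within the scatter) from compound 1 to compound 2 and an at least 1.7-fold higher number (0.23 log units; that floor lies within the scatter) from compound 3 to compound 4; the limit leaves it open whether they differ.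

From the compounds shown here alone, whether an amine or a carboxylic acid in place of the halogen on the benzyl group would shift the value in this assay stays open. The same holds for an unsubstituted benzyl or a longer chain in place of the halobenzyl group, on either core.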